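A few compounds are considered here, and "the series" means these few. Any claim that something is new, unique, unknown or untested is made for them only; others in the source may bear on it.

Of the compounds shown here, three on a shared core have so far been measured in an assay on LtK cells with ATP-sensitive inward rectifier potassium channel 11 (Homo sapiens) as the target; on this read-out higher numbers stand for an effect only at larger amounts of compound and lower numbers for an effect already at smaller amounts. Compound 1 `CC(C)CCC(=O)Nc1c(C(O)(C(F)(F)F)C(F)(F)F)ccc2ccccc12` gives 49 nM. Compound 2 `O=C(CCc1ccccc1)Nc1c(C(O)(C(F)(F)F)C(F)(F)F)ccc2ccccc12` gives 1750 nM, and compound 3 `O=C(Nc1c(C(O)(C(F)(F)F)C(F)(F)F)ccc2ccccc12)c1ccccc1Cl` gives 2040 nM. Compound 3 thus sits at the high end of the three numbers: the step of a 42-fold higher number from compound 1 to compound 3 (1.62 log units; beyond the scatter) was large, whereas the step of a 1.2-fold higher number from compound 2 to compound 3 (0.07 log units; within the scatter) lies within the scatter, so compound 2 and compound 3 cannot be separated on these data. Compound 4 `O=C(Nc1c(C(O)(C(F)(F)F)C(F)(F)F)ccc2ccccc12)c1cccc(Br)c1` has not yet been measured; it differs from compound 3 by 3-bromophenyl in place of 2-chlorophenyl on a carbonyl carbon. The measured steps that touch the carbonyl carbon exchange a whole chain for an aryl group, or one chain-bearing group for another; none exchanges one halogenated phenyl for another, so they bear only loosely on this change and give no direction for it. Compound 4 is therefore expected to show a 1.0-fold lower number from compound 3 to compound 4 (0.01 log units; within the scatter), a change not beyond the scatter. The value of compound 4 in this assay is estimated at 2000 nM, within 600 nM to 7000 nM.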

Compound 4, half-maximal effective concentration: 80 nM
The estimate for compound 4 lay 25-fold (1.40 log units) above the measured number, outside the stated range (below it).
By their numbers in this assay, from the lowest: compounds 1 and 4 (each within the scatter of the next); then compounds 2 and 3 (each within the scatter of the next).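

On a carbonyl carbon of the shared core, exchanging one halogenated phenyl for another proves far from neutral: in this assay, 3-bromophenyl in place of 2-chlorophenyl gives a large step (a 26-fold lower number from compound 3 to compound 4 (1.41 log units; beyond the scatter)), and 3-bromophenyl in place of phenethyl gives one of similar kind (a 22-fold lower number from compound 2 to compound 4 (1.34 log units; beyond the scatter)). An aryl group at this place therefore need not bring the high numbers of compound 2 and compound 3, since 3-bromophenyl and isopentyl cannot be separated on these data (a 1.6-fold higher number from compound 1 to compound 4 (0.21 log units; within the scatter)). Nothing at hand explains the difference between the two halogenated phenyl groups.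

Both the halogen and its place on the ring change in this step, so the compounds shown do not tell which of the two carries it. Compounds bearing 3-chlorophenyl, 2-bromophenyl or plain phenyl on the same carbonyl carbon would be needed to divide the two.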